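Methyl Removal on a Pyridyl Thiosemicarbazide Core

The compounds below may be only part of what the source reports. "The series", "measured", "known", "first", "only" and "open" are said of these compounds alone.

Measured compounds:
compound 1 `Cc1cccc(/C(N)=N/NC(=S)N2CCSCC2)n1` gives 53.2%
compound 2 `Cc1ccnc(/C(N)=N/NC(=S)N2CCN(c3ccccn3)CC2)c1` gives 44%
compound 3 `N/C(=N\NC(=S)N1CCSCC1)c1ccccn1` gives 61.4%

These three compounds were measured in a functional assay on A-431 cells (Homo sapiens) for cytotoxicity, read by MTT assay, with a stated time of 72 h, tested at 10 uM; a higher number here means more inhibition of growth at the concentration tested, a lower number less inhibition of growth. Compound 1 and compound 3 differ by hydrogen in place of methyl on an aromatic carbon, and that step reads a number 8.2 percentage points higher from compound 1 to compound 3 (within the scatter). Compound 2 shares a related core with compound 1, but the difference between the two cores is not broken down here. Compound 4 `N/C(=N\NC(=S)N1CCN(c2ccccn2)CC1)c1ccccn1` has not yet been measured; it differs from compound 2 by hydrogen in place of methyl on an aromatic carbon. This is the same kind of change as from compound 1 to compound 3, though the place differs: there the methyl sits next to the ring nitrogen, here it sits opposite the ring nitrogen. Since the measured step from compound 1 to compound 3 was a number 8.2 percentage points higher from compound 1 to compound 3 (within the scatter), a similarly small shift is expected from compound 2 to compound 4, namely a number 8 percentage points higher from compound 2 to compound 4 (within the scatter). Compound 4 is therefore estimated at 52%, between 38% and 66%.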

Compound 4, percent growth inhibition at one concentration: 69%
Compound 4: middle estimate off by 17 percentage points, on the low side, outside the stated range (above it).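

In this assay, placing hydrogen where methyl stood on the aromatic carbon opposite the ring nitrogen gives a number 25 percentage points higher from compound 2 to compound 4 (beyond the scatter). The same kind of change therefore does not carry over with the same size from one core to the other: the same change on two cores in this assay, a number 8.2 percentage points higher (within the scatter) from compound 1 to compound 3 and a number 25 percentage points higher (beyond the scatter) from compound 2 to compound 4, 16.8 percentage points apart, beyond the scatter of two such steps. Going by these compounds alone, with only two pairs, and with the methyl in a different place in each, this does not show whether the core or the place of the methyl sets the size of the step, nor why the two steps differ.

Still open, from the compounds shown here alone, is how a different group on that aromatic carbon, such as a chlorine atom, a methoxy group or an amine, would compare with methyl and hydrogen. Also open, going by these compounds, is how the change from methyl to hydrogen would read on further cores.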